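The source may hold more compounds than are shown below. What is called first, only, known or untested is meant among the compounds shown, and "the series" means these compounds.

Measured compounds in an assay on BTI-TN-5B1-4 cells for inhibition of Amine oxidase [flavin-containing] B (Homo sapiens), read by fluorescence and Amplex Red, using microsomes, with a stated time of 30 min; on this read-out lower numbers stand for stronger inhibition and higher numbers for weaker inhibition:
compound 1 `C#CCOc1ccc(-c2cc(-c3ccc(OCC#C)c(OC)c3)nc(N)n2)cc1` gives 20000 nM
compound 2 `C#CCOc1ccc(-c2cc(-c3ccc(OCC#C)c(OC)c3)nc(C)n2)cc1` gives 21100 nM
compound 3 `C#CCOc1ccccc1-c1cc(-c2ccccc2OCC#C)nc(N)n1` gives 11100 nM

Compound 1 stands second highest of the three numbers. Its nearest neighbour is compound 2, reached by a 1.1-fold higher number from compound 1 to compound 2 (0.02 log units; within the scatter), a change at the shared core that leaves the number where it was. Compound 3 is furthest from compound 1, yet the two values still lie within the scatter of each other, so no order between them can be stated; compound 3 also differs from compound 1 in more than one place, so only its value can be read.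

Compound 4 `C#CCOc1ccc(-c2cc(-c3ccc(OCC#C)c(OCC)c3)nc(N)n2)cc1` differs from compound 1 by methyl in place of hydrogen on a saturated chain carbon bound to an oxygen on an aromatic ring. Among the compounds with values here, no measured step touches this position: the single-place step from compound 1 to compound 2 concerns a different group on the core, and compound 3 carries the propargyloxy groups on different ring positions without the methoxy group at all. Within the data shown here, the series so far shows only changes that stay within the scatter, and nothing speaks for a change at the methoxy group behaving differently. A step of no size beyond the scatter is therefore expected in this assay, in either direction.

Compound 4 is estimated at 20000 nM, with a range from 8000 nM to 50000 nM. This estimate means a step of no change at the digits printed from compound 1 to compound 4 (within the scatter), which is expected to fall within the scatter.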

Compound 4, half-maximal inhibitory concentration: 14000 nM
Compound 4: middle estimate off by 1.4-fold (0.15 log units), on the high side; measured number inside the range.
By their numbers in this assay, from the lowest: compounds 3, 4, 1 and 2 (each within the scatter of the next).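

Within the data shown here, no earlier step touched the methoxy group; here, in this assay, lengthening methoxy to ethoxy gives a 1.4-fold lower number from compound 1 to compound 4 (0.15 log units; within the scatter). A methyl in place of hydrogen on a saturated chain carbon bound to an oxygen on an aromatic ring therefore leaves the number within the scatter, just as the change at the other measured place on the shared core does, with a 1.1-fold higher number from compound 1 to compound 2 (0.02 log units; within the scatter). No supporting data are available to explain this result.

Among these compounds, the single step covers only the move from methoxy to ethoxy, so it does not show whether a longer chain such as propoxy or butoxy, or a branched group such as isopropoxy, would also stay within the scatter. Also open, as far as these compounds go, is how this position responds to a hydroxyl group, or to a chain ending in an amine or a carboxylic acid, and whether any replacement here can move the number beyond the scatter at all.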